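The source may hold more compounds than are shown below. What is called first, only, known or untested is meant among the compounds shown, and "the series" means these compounds.

In a functional assay on HepG2 cells (Homo sapiens) for cytotoxicity, read by MTT assay, with a stated time of 48 h (on this read-out lower numbers stand for stronger inhibition and higher numbers for weaker inhibition), compound 1 `COc1cc2c(cc1OC)CN(S(=O)(=O)c1ccc(-n3cc(COc4ccc5ccccc5c4)nn3)cc1)CC2` gives 1260 nM, the lowest of the two numbers reported here. Compound 2 `O=Cc1ccc(OCc2cn(-c3ccc(S(=O)(=O)N4CCc5ccccc5C4)cc3)nn2)cc1` gives 5270 nM in this assay, a higher number than compound 1, and the gap between the two values lies beyond the usual scatter of repeated measurements.

Compound 3 `COc1cc2c(cc1OC)CN(S(=O)(=O)c1ccc(-n3cc(CO)nn3)cc1)CC2` has not yet been measured. It differs from compound 1 in one place: hydrogen in place of naphthalen-2-yl on an oxygen on a saturated carbon. Put simply, the naphthalen-2-yl group is removed, so that the ((naphthalen-2-yl)oxy)methyl arm becomes a hydroxymethyl arm on the shared core of compound 1.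

For the measured compounds named here, no pair of measured compounds differs by this change, so no measured step can be consulted. The expectation is nevertheless that the loss of the naphthalen-2-yl group is felt: compound 3 is estimated to give a higher number than compound 1, a step of a 6.3-fold higher number from compound 1 to compound 3 (0.80 log units; beyond the scatter) that is expected to exceed the scatter. Compound 3 is therefore estimated at 8000 nM in this assay, with a range from 2500 nM to 30000 nM.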

Compound 3, half-maximal inhibitory concentration: 31800 nM
The estimate for compound 3 lay 4.0-fold (0.60 log units) below the measured number; the measured number lies above the stated range.
By their numbers in this assay, from the lowest: compound 1; then compound 2; then compound 3.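

In this assay, taking the naphthalen-2-yl group off the oxygen on a saturated carbon gives a 25-fold higher number from compound 1 to compound 3 (1.40 log units; beyond the scatter), a large step and the first that can be read at this position. The earlier compounds shown here differed in more than one place, so they could not separate this arm from the rest of the structure; this pair shows that, on the shared core of compound 1, the ((naphthalen-2-yl)oxy)methyl arm goes with a much lower number than the hydroxymethyl arm. Nothing given here explains why the step is so large.

The compounds shown give only the two ends of this change, so it remains open whether a phenyl or a benzyl group on the same oxygen would keep the number near that of compound 1 or leave it closer to that of compound 3. Also open, on these data alone, is how an amine or a carboxylic acid in place of the hydroxy group would read, and whether the step keeps its size on a different core.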